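The source may report more compounds than this note shows. Statements on the series, on what has been measured and on what is new or still open speak of the compounds shown alone.

Measured so far, in an assay on isolated protein for inhibition of protein deacetylase HDAC6 (Homo sapiens), read by fluorescence; on this read-out lower numbers stand for stronger inhibition and higher numbers for weaker inhibition:
compound 1 `Cn1cc(-c2cc(C(C)(C)O)ccc2OC2CC2)c2cc(C(=O)NCc3ccc(C(=O)NO)cc3)[nH]c2c1=O` gives 7.9 nM
compound 2 `Cn1cc(-c2cc(C(C)(C)O)ccc2Oc2ccc(F)cc2F)c2cc(C(=O)NCc3ccc(C(=O)NO)cc3)[nH]c2c1=O` gives 15.6 nM

Of these two numbers, that of compound 2 lies further up, yet only by a 2.0-fold higher number from compound 1 to compound 2 (0.30 log units; within the scatter), a difference inside the scatter. Compound 3 `CC(C)Oc1ccc(C(C)(C)O)cc1-c1cn(C)c(=O)c2[nH]c(C(=O)NCc3ccc(C(=O)NO)cc3)cc12` carries isopropyl in place of 2,4-difluorophenyl on an oxygen on an aromatic ring. Among the compounds with values here, the one step that bears on this place, a 2.0-fold higher number from compound 1 to compound 2 (0.30 log units; within the scatter), stayed within the scatter when a small carbon group was exchanged for the 2,4-difluorophenyl, so the reverse direction of exchange to isopropyl is expected to move little: a 1.6-fold lower number from compound 2 to compound 3 (0.19 log units; within the scatter) is the estimate. Compound 3 is therefore expected to give about 10 nM in this assay, within 4 nM to 25 nM.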

Compound 3, half-maximal inhibitory concentration: 52 nM
For compound 3 the middle estimate is 5.2-fold (0.72 log units) below the measured one; measured number outside the range, above it.
By their numbers in this assay, from the lowest: compounds 1 and 2 (each within the scatter of the next); then compound 3.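

The oxygen substituent is not as tolerant as the first pair suggested: in this assay, replacing 2,4-difluorophenyl with isopropyl gives a 3.3-fold higher number from compound 2 to compound 3 (0.52 log units; beyond the scatter), a change beyond the scatter. Replacing cyclopropyl with isopropyl also goes beyond the scatter, with a 6.6-fold higher number from compound 1 to compound 3 (0.82 log units; beyond the scatter), so among these three compounds, the two with a ring on this oxygen give lower numbers than the one with the open-chain group. Nothing available explains this difference. Still open, as far as these compounds go, is whether a methyl group or a longer chain such as n-butyl would behave like isopropyl or like the ring-bearing groups.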